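Extending the amine side chain of compound 1 with a phenyl group

This account rests on a few compounds, and the source may have more. Where it says the series, first, only, none or still open, it means among the compounds named here.

Three compounds share one core and differ only in the group carried on the amine nitrogen. Compound 1 `OCCNCc1nc2c(OCC3CCCCC3)cccc2[nH]1` carries a 2-hydroxyethyl group; in an assay on cells for inhibition of interleukin-5 receptor subunit alpha (Mus musculus), read by WST assay, with a stated time of 48 h, in the presence of a further agent that is not named here (on this read-out lower numbers stand for stronger inhibition and higher numbers for weaker inhibition), compound 1 gives 20000 nM. Compound 2 `OCCCCNCc1nc2c(OCC3CCCCC3)cccc2[nH]1` carries a 4-hydroxybutyl group and gives 30000 nM. Compound 3 `CC(C)(CO)NCc1nc2c(OCC3CCCCC3)cccc2[nH]1` carries a 1-(hydroxymethyl)-1-methylethyl group and gives 27500 nM. The steps among them are small: a 1.5-fold higher number from compound 1 to compound 2 (0.18 log units; within the scatter), a 1.4-fold higher number from compound 1 to compound 3 (0.14 log units; within the scatter) and a 1.1-fold lower number from compound 2 to compound 3 (0.04 log units; within the scatter). Compound 1 thus stands within the scatter of both others, and none of the three can be set apart.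

Compound 4 `OCC(NCc1nc2c(OCC3CCCCC3)cccc2[nH]1)c1ccccc1` is made from compound 1 by the change (phenyl in place of hydrogen on a saturated chain carbon bound to an amine nitrogen and a saturated chain carbon). Among the measured compounds shown here, no measured step bears directly on a phenyl at this position; the measured steps only show that the side chain on the amine nitrogen can be lengthened or branched without a shift beyond the scatter. On that basis compound 4 is expected to stay close to compound 1, a step of no change at the digits printed from compound 1 to compound 4 (within the scatter), giving an estimated value of 20000 nM with a range from 5000 nM to 60000 nM.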

Compound 4, half-maximal inhibitory concentration: 20000 nM
The estimate for compound 4 equals the measured number at the digits printed; measured number inside the range.
By their numbers in this assay, from the lowest: compounds 1, 4, 3 and 2 (each within the scatter of the next).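

In this assay, a phenyl group can take the place of hydrogen on the saturated chain carbon bound to an amine nitrogen and a saturated chain carbon without a shift beyond the scatter (no change at the digits printed from compound 1 to compound 4 (within the scatter)), so the tolerance seen for lengthening and branching the side chain also extends to an aromatic ring of carbon. Compound 4 also stays within the scatter of the other two side chains (a 1.4-fold lower number from compound 3 to compound 4 (0.14 log units; within the scatter); a 1.5-fold lower number from compound 2 to compound 4 (0.18 log units; within the scatter)), which leaves all four compounds impossible to set apart. No evidence is available to explain this result.

The compounds shown leave open whether any change to this side chain can move the number beyond the scatter. As far as these compounds go, a pyridine ring in place of the phenyl, or an amine or a carboxylic acid in place of the hydroxy group, remains untested among them.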